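A few compounds are considered here, and "the series" means these few. Any claim that something is new, unique, unknown or untested is made for them only; others in the source may bear on it.

Among the compounds with values here, compound 3 `CNCCNc1cc(N2CCCc3ccc(F)cc3C2)nc2ccc(C)cc12` gives 29000 nM in an ADME assay on HEp-2 cells (Homo sapiens) for cytotoxicity, read by CCK-8 assay, with a stated time of 5 days (a lower number here means that less compound is tolerated, a higher number that more compound is tolerated), the highest of the three numbers so far; compound 2 `CS(=O)(=O)c1ccc2nc(N3CCCc4ccccc4C3)cc(NCCN)c2c1` gives 13000 nM and compound 1 `NCCNc1cc(N2CCCc3ccccc3C2)nc2ccc(C(F)(F)F)cc12` gives 6700 nM in this assay. Compound 4 `Cc1ccc2nc(N3CCCc4ccc(F)cc4C3)cc(NC(C)(C)CN)c2c1` differs from compound 3 by 1-(aminomethyl)-1-methylethyl in place of 2-(methylamino)ethyl on a nitrogen on an aromatic ring. Within the data shown here, the only measured single step, a 1.9-fold higher number from compound 1 to compound 2 (0.29 log units; within the scatter), concerns a group on an aromatic carbon and tells nothing about the diamine chain, so no measured step bears on this change. With nothing pointing either way, the step in this assay is expected to be a 1.1-fold lower number from compound 3 to compound 4 (0.03 log units; within the scatter), nothing beyond the scatter. Compound 4 is therefore estimated at 27000 nM in this assay, with a range from 11000 nM to 65000 nM.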

Compound 4, half-maximal cytotoxic concentration: 25000 nM
For compound 4 the middle estimate is 1.1-fold (0.03 log units) above the measured one; the measured number falls inside the stated range.
By their numbers in this assay, from the lowest: compounds 1, 2, 4 and 3 (each within the scatter of the next, the first and the last beyond it).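

Within the data shown here, this is the only measured step at this place, on a nitrogen on an aromatic ring, and in this assay the exchange of 2-(methylamino)ethyl for 1-(aminomethyl)-1-methylethyl gives a step within the scatter (a 1.2-fold lower number from compound 3 to compound 4 (0.06 log units; within the scatter)). The two chains are therefore not told apart in this assay, on this core. No evidence is at hand that bears on this result.

Still open, going by these compounds, is whether a longer chain, a piperidine or an alcohol in place of the amine would give a step beyond the scatter. Also open, on these data alone, is whether this exchange would behave alike on the core of compound 1.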